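Sulfonamide and amide indole analogues: antiproliferative working notes

A few compounds are considered here, and "the series" means these few. Any claim that something is new, unique, unknown or untested is made for them only; others in the source may bear on it.

Measured so far in a functional assay on MCF7 cells (Homo sapiens) for antiproliferative activity, read by MTT assay, with a stated time of 24 h; on this read-out lower numbers stand for stronger inhibition and higher numbers for weaker inhibition:
compound 1, `O=S(=O)(Nc1ccc2cc[nH]c2c1)c1ccc(F)cc1`: 30900 nM
compound 2, `O=S(=O)(Nc1ccc2cc[nH]c2c1)c1ccc(Br)cc1`: 37800 nM
compound 3, `O=C(Nc1ccc2cc[nH]c2c1)c1ccc(Br)cc1`: 38100 nM

Compound 1 and compound 2 share one core; compound 3 carries a different core, and the difference between the two cores is not broken down here. The three numbers sit close together, all within the scatter of one another, so no order among them is claimed.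

Compound 2 and compound 1 differ by fluoro in place of bromo on an aromatic carbon. The step was a 1.2-fold lower number from compound 2 to compound 1 (0.09 log units; within the scatter).

Compound 4, `O=C(Nc1ccc2cc[nH]c2c1)c1ccc(F)cc1`, has not yet been measured in this assay. It differs from compound 3 by fluoro in place of bromo on an aromatic carbon, the same change at the same place as between compound 2 and compound 1. Among the measured compounds shown here, since the one earlier step of this kind stayed within the scatter, the step expected for compound 4 is a 1.1-fold lower number from compound 3 to compound 4 (0.05 log units; within the scatter). For compound 4 the estimated value is 34000 nM, expected to fall between 17000 nM and 70000 nM.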

Compound 4, half-maximal inhibitory concentration: 45900 nM
Compound 4: the middle estimate sits 1.4-fold (0.13 log units) below what was measured, within the range that was stated.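

In this assay, fluoro in place of bromo on an aromatic carbon gives a 1.2-fold higher number from compound 3 to compound 4 (0.08 log units; within the scatter), so on this core too the change stays within the scatter. Set beside the earlier step, the new one shows no difference between the two cores: the same change on two cores in this assay, a 1.2-fold lower number (0.09 log units; within the scatter) from compound 2 to compound 1 and a 1.2-fold higher number (0.08 log units; within the scatter) from compound 3 to compound 4, 1.5-fold (0.17 log units) apart, within the scatter of two such steps. The change therefore carries across these two cores with no visible effect on the number, but this does not show that it would behave the same way on any other core, or that a step large enough to read would carry over.

The compounds shown leave open whether an amine, a carboxylic acid or a methoxy group in this place would move the number beyond the scatter on either core. As far as these compounds go, whether any group here separates the two cores also remains open.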